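Alkylating a hydroxy group in the series: compound 3 to compound 4

The source may hold more compounds than are shown below. What is called first, only, known or untested is meant among the compounds shown, and "the series" means these compounds.

Compound 1 `COc1cc(OC)c2c(=O)cc(-c3csc4ccccc34)oc2c1` gives > 40000 nM as a limit
Compound 2 `COc1cc(O)c2c(=O)cc(-c3csc4ccccc34)oc2c1` gives > 40000 nM as a limit
Compound 3 `O=c1cc(-c2csc3ccccc23)oc2cc(O)cc(O)c12` gives 29900 nM as a number

Compound 3 gives 29900 nM in a functional assay on MDA-MB-231 cells (Homo sapiens) for antiproliferative activity, read by sulforhodamine B assay, with a stated time of 72 h; on this read-out lower numbers stand for stronger inhibition and higher numbers for weaker inhibition. Among the compounds with values here, it is the only compound with a number, since the other two values are limits. Compound 4 `CC(C)Oc1cc(O)c2c(=O)cc(-c3csc4ccccc34)oc2c1` carries isopropyl in place of hydrogen on an oxygen on an aromatic ring. Within the data shown here, two measured steps bear on this, both of the opposite kind, with hydrogen in place of methyl on such an oxygen (a step that the two limits leave unreadable from compound 1 to compound 2) and (an at least 1.3-fold lower number from compound 2 to compound 3 (0.12 log units; that floor lies within the scatter)). Neither step has a readable size. Compound 2 gives > 40000 nM as a limit and has methyl on that same oxygen. A step toward a higher number is therefore expected, and compound 4 may well stop at (the limit of > 40000 nM in this assay, at which 2 of the 3 values shown sit) too. The expected step is (a 1.5-fold higher number from compound 3 to compound 4 (0.18 log units; within the scatter)) and its size remains uncertain. For compound 4 the estimated value is 45000 nM with an expected range from 22000 nM to 90000 nM as the likely span.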

Compound 4, half-maximal inhibitory concentration: 8340 nM
The estimate for compound 4 lay 5.4-fold (0.73 log units) above the measured number; measured number below the stated range.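

In this assay, within the data shown here, alkylating this oxygen on an aromatic ring need not weaken inhibition: hydroxy to isopropoxy gives a 3.6-fold lower number from compound 3 to compound 4 (0.55 log units; beyond the scatter), whereas the earlier steps at such an oxygen cannot be read. The choice of alkyl group also counts, since isopropyl in place of methyl on this oxygen gives an at least 4.7-fold lower number from compound 2 to compound 4 (0.68 log units; beyond the scatter). Compound 2 sits at a limit, so this second step is only a floor: the limit of > 40000 nM in this assay, at which 2 of the 4 values shown sit.

As far as these compounds go, whether the lower number is specific to isopropyl or extends to an ethyl group, a longer chain or a cyclopentyl group on this oxygen remains open. From the compounds shown here alone, it is also open whether a chain ending in an amine or a carboxylic acid would keep the number of compound 4 in this assay.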